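This account rests on a few compounds, and the source may have more. Where it says the series, first, only, none or still open, it means among the compounds named here.

In a functional assay on NALM-6 cells (Homo sapiens) for cytotoxicity, read by MTT assay, with a stated time of 48 h (on this read-out lower numbers stand for stronger inhibition and higher numbers for weaker inhibition), three compounds that share one core have been measured so far. Compound 1 `C=C1C(=O)OC(C)CC1c1ccccc1OC` gives 6260 nM, and compound 2 `C=C1C(=O)O[C@H](C)[C@@H]1c1ccc(Br)cc1` gives 4250 nM. Compound 3 `C=C1C(=O)O[C@@H](C)[C@@H]1c1ccc(Br)cc1` has the same atoms and bonds as compound 2 and differs from it only in configuration as drawn. Compound 3 gives 1100 nM, the lowest of the three numbers; the step of a 3.9-fold lower number from compound 2 to compound 3 (0.59 log units; beyond the scatter) lies beyond the scatter, and the only thing known about it is the fact that compounds 2 and 3 differ only in the configuration as drawn. Compound 4 `C=C1C(=O)O[C@@H](C)[C@@H]1c1ccc(C)cc1` differs from compound 3 by methyl in place of bromo on an aromatic carbon. Going by the values given here, no measured step covers this exchange: the single measured step, from compound 2 to compound 3, concerns configuration alone, and compound 1 differs from the other two in more than one place. Among the compounds with values here, the expectation for compound 4 therefore rests on no directly comparable step, and a change of modest size in either direction, or none beyond the scatter, is expected for a 1.8-fold higher number from compound 3 to compound 4 (0.26 log units; within the scatter). For compound 4 in this assay the estimate is 2000 nM, with a range from 700 nM to 6000 nM.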

Compound 4, half-maximal inhibitory concentration: 4390 nM
For compound 4 the middle estimate is 2.2-fold (0.34 log units) below the measured one, within the range that was stated.
By their numbers in this assay, from the lowest: compound 3; then compounds 2, 4 and 1 (each within the scatter of the next).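

In this assay, going by these compounds alone, the exchange of bromo for methyl on this aromatic carbon is the only measured step that touches the aromatic ring, and a 4.0-fold higher number from compound 3 to compound 4 (0.60 log units; beyond the scatter) shows that the group at this place counts for the number as well as the configuration does. Compound 3 now stands as the compound from which each of the two measured single changes, one in configuration and one in this group, leads to a higher number. Nothing known about these compounds bears on why the exchange has this size.

Going by these compounds, what remains open is whether the same exchange would give a step of similar size in the configuration of compound 2. Also open, on these data alone, is how a chloro group, an amine or a carboxylic acid on the same aromatic carbon would compare with bromo and methyl.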